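Aryl amide change on a shared core

This account rests on a few compounds, and the source may have more. Where it says the series, first, only, none or still open, it means among the compounds named here.

Compound 2 `COc1ccc(NC(=O)/C=C/c2coc3cc(O)ccc3c2=O)cc1` carries a 4-methoxyphenyl group on the amide-type nitrogen. For the measured compounds named here, in a functional assay on A549 cells (Homo sapiens) for inhibition, read by MTT assay, with a stated time of 48 h (on this read-out lower numbers stand for stronger inhibition and higher numbers for weaker inhibition), compound 2 gives 12800 nM, the only numerical value shown for this set. Compound 1 `O=C(/C=C/c1coc2cc(O)ccc2c1=O)NCc1ccc(F)cc1` bears a 4-fluorobenzyl group at the same nitrogen. In this assay compound 1 gives only a limit, > 100000 nM. Going by the values given here, the step of an at least 7.8-fold lower number from compound 1 to compound 2 (0.89 log units; beyond the scatter) is the single measured step at this position, and its size is known only as a bound given (the limit of > 100000 nM in this assay, at which 1 of the 2 values shown sits). Compound 3 `Cc1ccccc1NC(=O)/C=C/c1coc2cc(O)ccc2c1=O` is the next compound, with 2-methylphenyl in place of 4-methoxyphenyl on an amide-type nitrogen. The measured step swaps a benzyl for an aryl group, whereas here one aryl group replaces another, so it bears only loosely on this change. A step within the scatter or a modest rise in number is expected, estimated as a 1.6-fold higher number from compound 2 to compound 3 (0.19 log units; within the scatter). Compound 3 is therefore estimated at 20000 nM, with a range from 6000 nM to 80000 nM.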

Compound 3, half-maximal inhibitory concentration: > 100000 nM
Compound 3: a limit, no number; the forecaster's own chance of this, stated with the estimate: 25%; at least 5.0-fold (0.69 log units) between middle value and limit.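

In this assay the result gives an at least 7.8-fold higher number from compound 2 to compound 3 (0.89 log units; beyond the scatter), so this position responds to an exchange of one aryl group for another, and not only to the change from a benzyl to an aryl group. An aryl group on the amide-type nitrogen is therefore not enough by itself to give a number, since compound 3 carries one and still ends at a limit. The step between compound 1 and compound 3 cannot be read, because both values are limits: the limit of > 100000 nM in this assay, at which 2 of the 3 values shown sit.

On these data alone, only compound 2 has a number, so the true size of its gap to compound 3 remains open. As far as these compounds go, it is also open whether 2-methoxyphenyl, 4-methylphenyl or 4-aminophenyl on this nitrogen would give a number in this assay, which would separate the identity of the added group from its place on the ring.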